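This account rests on a few compounds, and the source may have more. Where it says the series, first, only, none or still open, it means among the compounds named here.

Of the compounds shown here, two sharing one core have been measured in an assay on isolated protein for inhibition of histone deacetylase HD2 (Zea mays); on this read-out higher numbers stand for weaker inhibition and lower numbers for stronger inhibition. Compound 1 `O=C(CCCSc1nc(O)cc(-c2ccccc2)n1)NO` gives a half-maximal inhibitory concentration of 27 nM. Compound 2 `CC(c1ccccc1)c1cc(O)nc(SCCCCCC(=O)NO)n1` gives 9 nM, the lower of the two numbers, and its gap to compound 1 lies beyond the usual scatter of this assay. Compound 3 `CCC(c1ccccc1)c1cc(O)nc(SCCCCCC(=O)NO)n1` has not yet been measured. It differs from compound 2 in a single place: methyl in place of hydrogen on a saturated chain carbon, two bonds along the chain from two aromatic carbons, so that methyl becomes ethyl. For the measured compounds named here, no pair of measured compounds shows this change, so nothing measured tells how large a step it brings. A change this small is expected to leave the number close to that of compound 2, within the scatter. The step expected from compound 2 to compound 3 is no change at the digits printed from compound 2 to compound 3 (within the scatter). Compound 3 is therefore estimated at 9 nM, with a range from 3 nM to 30 nM.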

Compound 3, half-maximal inhibitory concentration: 32 nM
Compound 3: the middle estimate sits 3.6-fold (0.55 log units) below what was measured, outside the stated range (above it).
By their numbers in this assay, from the lowest: compound 2; then compounds 1 and 3 (each within the scatter of the next).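

In this assay, the change from methyl to ethyl on this saturated chain carbon, two bonds along the chain from two aromatic carbons, gives a step beyond the scatter: a 3.6-fold higher number from compound 2 to compound 3 (0.55 log units; beyond the scatter), towards weaker inhibition. For the compounds shown here, the earlier compounds held no pair differing at this place, so this is the first sign that the position responds to a single added carbon, and that the response, though modest, is not negligible. Nothing at hand explains this step.

Going by these compounds, whether a propyl group on this carbon would weaken inhibition further, or whether a hydroxyl group or a fluorine atom there would behave like ethyl, remains open. A single step gives one direction at one place, not a trend along a series.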